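Swapping the 2-aminophenyl for a 3-methylphenyl

A few compounds are considered here, and "the series" means these few. Any claim that something is new, unique, unknown or untested is made for them only; others in the source may bear on it.

Compound 1, `COC(=O)C1=C(C)N=C(C)/C(=C(\O)OC)C1c1ccc(Cl)cc1`: 8130 nM
Compound 2, `COC(=O)C1=C(C)N=C(C)/C(=C(\O)OC)C1c1ccccc1N`: 39800 nM

Both numbers come from a functional assay (muscle tissue) with Cavia porcellus as the target; a higher number here means that more compound is needed for the effect, a lower number that less compound is needed. Within the data shown here, compound 2 stands highest of the two; its only neighbour is reached by a 4.9-fold higher number from compound 1 to compound 2 (0.69 log units; beyond the scatter), a modest step.

Compound 3, `COC(=O)C1=C(C)N=C(C)/C(=C(\O)OC)C1c1cccc(C)c1`, differs from compound 2 in one place: 3-methylphenyl in place of 2-aminophenyl on a saturated ring carbon. Among the measured compounds shown here, the one measured step that bears on this is a 4.9-fold higher number from compound 1 to compound 2 (0.69 log units; beyond the scatter), which brought the 2-aminophenyl in; taking it out again for a group with no hydrogen-bond donor or acceptor is expected to reverse much of that step. Compound 3 is therefore expected to give about 10000 nM, between 3000 nM and 35000 nM. That estimate means an expected step of a 4.0-fold lower number from compound 2 to compound 3 (0.60 log units; beyond the scatter).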

Compound 3, half-maximal effective concentration: 110 nM
Beside the measured number, compound 3's estimate is 91-fold (1.96 log units) above it; the measured number lies below the stated range.
By their numbers in this assay, from the lowest: compound 3; then compound 1; then compound 2.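

In this assay the group on this saturated ring carbon can move the number much further than the first pair showed: there is a 360-fold lower number from compound 2 to compound 3 (2.56 log units; beyond the scatter) and also a 74-fold lower number from compound 1 to compound 3 (1.87 log units; beyond the scatter) with the 3-methylphenyl giving the lowest number of the three. Nothing available here accounts for steps of this size.

On these data alone, these compounds change the substituent and its place on the phenyl ring together, so the part played by the methyl itself stays open. A 2-methylphenyl, a 4-methylphenyl or a 3-chlorophenyl would help separate the two.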